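Ether substituent change from compound 2 to compound 3

The compounds below may be only part of what the source reports. "The series", "measured", "known", "first", "only" and "open" are said of these compounds alone.

Compound 1 `O=C1OCCN1C(=O)c1ccc(Oc2ccccc2)cc1` gives 680 nM in an assay on HEK293 cells for inhibition of N-acylethanolamine-hydrolyzing acid amidase (Rattus norvegicus), read by LC-MS, with a stated time of 30 min; a higher number here means a weaker inhibitor, a lower number a stronger inhibitor.
Compound 2 `CCCCOc1ccc(C(=O)N2CCOC2=O)cc1` gives 1340 nM in this assay.

Going by the values given here, compound 2 has the highest of the two numbers so far; its nearest neighbour is compound 1, and the step of a 2.0-fold higher number from compound 1 to compound 2 (0.29 log units; within the scatter) lies within the scatter, so no order between the two can be stated.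

Compound 3 `O=C1OCCN1C(=O)c1ccc(OC2CCC(O)CC2)cc1` is not yet measured. It differs from compound 2 by 4-hydroxycyclohexyl in place of butyl on an oxygen on an aromatic ring. Among the compounds with values here, the only measured step at this position is a 2.0-fold higher number from compound 1 to compound 2 (0.29 log units; within the scatter), an exchange of one group on the aryl oxygen for another that stayed within the scatter. Within the data shown here, no measured step involves a hydroxyl or a saturated ring, so nothing speaks for a large move in either direction. The expected step in this assay is therefore a 1.1-fold higher number from compound 2 to compound 3 (0.05 log units; within the scatter), none beyond the scatter. Compound 3 is estimated at 1500 nM, with a range from 500 nM to 5000 nM.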

Compound 3, half-maximal inhibitory concentration: 210 nM
For compound 3 the middle estimate is 7.1-fold (0.85 log units) above the measured one; measured number outside the range, below it.
By their numbers in this assay, from the lowest: compound 3; then compounds 1 and 2 (each within the scatter of the next).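

The group on an oxygen on an aromatic ring can move the number beyond the scatter in this assay: 4-hydroxycyclohexyl gives a 6.4-fold lower number from compound 2 to compound 3 (0.80 log units; beyond the scatter) in place of butyl, and a 3.2-fold lower number from compound 1 to compound 3 (0.51 log units; beyond the scatter) in place of phenyl. Compound 3 is therefore the strongest inhibitor of the three, whereas compound 1 and compound 2 cannot be ordered, so this position is not indifferent to the group it carries. No information is available that accounts for this gain.

The hydroxyl and the six-membered ring enter together, so the compounds shown do not tell which of them carries the step; a plain cyclohexyl would separate the two. Going by these compounds, it also remains open whether an amine in place of the hydroxyl, or a butyl chain ending in a hydroxyl, would give a similar number.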